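Aminochromone series: cytotoxicity notes on one substituent change

The compounds below may be only part of what the source reports. "The series", "measured", "known", "first", "only" and "open" are said of these compounds alone.

Measured in an ADME assay on MT4 cells (Homo sapiens) for cytotoxicity, read by MTT assay, with a stated time of 4 days; a lower number here means that less compound is tolerated, a higher number that more compound is tolerated:
compound 1 `Nc1ccc2oc(-c3cccc(F)c3)c(O)c(=O)c2c1` gives 35300 nM
compound 2 `Nc1ccc2oc(-c3cccc(C(F)(F)F)c3)c(O)c(=O)c2c1` gives 8100 nM
compound 3 `COc1c(-c2cccc(F)c2)oc2ccc(N)cc2c1=O` gives 113000 nM

Among the measured compounds shown here, compound 2 differs from compound 1 by trifluoromethyl in place of fluoro on an aromatic carbon; the step of a 4.4-fold lower number from compound 1 to compound 2 (0.64 log units; beyond the scatter) is the only measured instance of this change. Compound 3 differs from compound 1 by methyl in place of hydrogen on an oxygen on an aromatic ring, with the step of a 3.2-fold higher number from compound 1 to compound 3 (0.51 log units; beyond the scatter), and stands highest of the three in this assay.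

Compound 4 `COc1c(-c2cccc(C(F)(F)F)c2)oc2ccc(N)cc2c1=O` is not yet measured. It differs from compound 3 by trifluoromethyl in place of fluoro on an aromatic carbon, the same change as from compound 1 to compound 2, on the core of compound 3 rather than that of compound 1. The expected step is a 4.4-fold lower number from compound 3 to compound 4 (0.64 log units; beyond the scatter), set beside a 4.4-fold lower number from compound 1 to compound 2 (0.64 log units; beyond the scatter), on the assumption that the change carries over between the two cores, which rests on one pair only. Compound 4 is therefore estimated at 25700 nM in this assay, within 8000 nM to 80000 nM.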

Compound 4, half-maximal cytotoxic concentration: 73100 nM
The estimate for compound 4 lay 2.8-fold (0.45 log units) below the measured number; measured number inside the range.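

In this assay, trifluoromethyl in place of fluoro on an aromatic carbon gives a 1.5-fold lower number from compound 3 to compound 4 (0.19 log units; within the scatter), so this change does not carry over in size between the two cores: the same change on two cores in this assay, a 4.4-fold lower number (0.64 log units; beyond the scatter) from compound 1 to compound 2 and a 1.5-fold lower number (0.19 log units; within the scatter) from compound 3 to compound 4, 2.8-fold (0.45 log units) apart, beyond the scatter of two such steps. Methyl in place of hydrogen on an oxygen on an aromatic ring gives a 9.0-fold higher number from compound 2 to compound 4 (0.96 log units; beyond the scatter), and this change also differs in size between the two cores: the same change on two cores in this assay, a 3.2-fold higher number (0.51 log units; beyond the scatter) from compound 1 to compound 3 and a 9.0-fold higher number (0.96 log units; beyond the scatter) from compound 2 to compound 4, 2.8-fold (0.45 log units) apart, beyond the scatter of two such steps. Both comparisons rest on the same four compounds, so they show that the two changes do not act independently here, but not why, nor how either change would behave on any other core.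

The compounds shown leave open whether a chlorine or a methoxy group in place of fluoro would follow compound 2 or compound 4. They also leave open whether an ethyl group or a longer chain on that oxygen would behave as methyl does.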